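The source may hold more compounds than are shown below. What is called first, only, known or untested is meant among the compounds shown, and "the series" means these compounds.

Measured so far in a functional assay for inhibition, with Cavia porcellus as the target; on this read-out lower numbers stand for an effect already at smaller amounts and higher numbers for an effect only at larger amounts of compound:
- compound 1 `CCCCOC(=O)CCCc1cc(CN2CCCC2)c(O)c(CN2CCCC2)c1`: 0.33 ug/mL
- compound 2 `CC(C)OC(=O)c1cc(CN2CCCC2)c(O)c(CN2CCCC2)c1`: 11.4 ug/mL
- compound 3 `CC(C)COC(=O)CCc1cc(CN2CCCC2)c(O)c(CN2CCCC2)c1`: 14 ug/mL

Compound 2 stands second highest of the three numbers; its nearest neighbour is compound 3, with a 1.2-fold higher number from compound 2 to compound 3 (0.09 log units; within the scatter), and its furthest is compound 1, with a 42-fold higher number from compound 1 to compound 3 (1.63 log units; beyond the scatter) standing between that compound and compound 3.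

The step to compound 4 `O=C(O)c1cc(CN2CCCC2)c(O)c(CN2CCCC2)c1` is hydrogen in place of isopropyl on an oxygen next to a carbonyl group. Within the data shown here, none of the measured steps touches this oxygen; both concern the carbon chain or the alkyl part of the isopropoxycarbonyl group. The step from compound 2 to compound 3 shows that swapping isopropoxycarbonyl for 2-(isobutoxycarbonyl)ethyl stays within the scatter, while the step from compound 1 to compound 3 shows that a change in the chain can be large. For the isopropyl to hydrogen change there is no shown precedent, so the direction cannot be read from the data and the expectation is wide. For compound 4 the number in this assay is estimated at 15 ug/mL, range 4 ug/mL to 60 ug/mL. This estimate for compound 4 means a step of a 1.3-fold higher number from compound 2 to compound 4 (0.12 log units; within the scatter), expected to stay near the number of compound 2.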

Compound 4, concentration for half-maximal effect: > 30 ug/mL
Compound 4 ended at the assay's limit; the forecaster's own chance of this, stated with the estimate: 15%; middle value at least 2.0-fold (0.30 log units) away from the limit.
By their numbers in this assay, from the lowest: compound 1; then compounds 2 and 3 (each within the scatter of the next). At a limit, above all of these: compound 4.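

Hydrogen in place of isopropyl on an oxygen next to a carbonyl group is the first change shown at this oxygen, and in this assay it gives an at least 2.6-fold higher number from compound 2 to compound 4 (0.42 log units; beyond the scatter). Carboxy in place of 2-(isobutoxycarbonyl)ethyl on an aromatic carbon gives an at least 2.1-fold higher number from compound 3 to compound 4 (0.33 log units; beyond the scatter), so the carboxy compound reads higher than both esters, whose own step stayed within the scatter. The value of compound 4 is a limit and not a number, so both steps give only a minimum size: the limit of > 30 ug/mL in this assay, at which 1 of the 4 values shown sits.

The compounds shown leave open how a methyl ester or a primary amide would read in place of the isopropoxycarbonyl group. Also open, on these data alone, is whether the longer chain of compound 1 would show a similar step with hydrogen in place of butyl on its ester oxygen.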